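Working notes: aryl change from compound 2 to compound 4

The source may hold more compounds than are shown below. What is called first, only, known or untested is meant among the compounds shown, and "the series" means these compounds.

Measured in an ADME assay on L02 cells (Homo sapiens) for cytotoxicity, read by MTT assay, with a stated time of 24 h; a higher number here means a weaker inhibitor, a lower number a stronger inhibitor:
- compound 1 `COc1cc(/C=C2\CN(C)C/C(=C\c3cccnc3)C2=O)cc(OC)c1`: 18400 nM
- compound 2 `CN1C/C(=C\c2cccnc2)C(=O)/C(=C/c2ccccc2F)C1`: 15900 nM
- compound 3 `CN1C/C(=C\c2cccnc2)C(=O)/C(=C/c2cc([N+](=O)[O-])ccc2F)C1`: 15700 nM

Compound 2, at 15900 nM, lies within the scatter of both compound 1 and compound 3, so the three values form one flat group. Compound 4 `CN1C/C(=C\c2cccnc2)C(=O)/C(=C/c2ccc(F)cc2Br)C1` is the next to be read, and its change from compound 2 is 2-bromo-4-fluorophenyl in place of 2-fluorophenyl on a double-bonded chain carbon bound to a double-bonded ring carbon. Going by the values given here, one measured step bears on this aryl group: a 1.0-fold lower number from compound 2 to compound 3 (0.01 log units; within the scatter), a nitro in place of hydrogen on an aromatic carbon. Among the compounds with values here, no measured step covers bromine. No step beyond the scatter is therefore expected in this assay. The estimated result is a 1.1-fold lower number from compound 2 to compound 4 (0.03 log units; within the scatter). The expected value for compound 4 is 15000 nM, with an estimated range of 8500 nM to 25000 nM.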

Compound 4, half-maximal inhibitory concentration: 14400 nM
For compound 4 the middle estimate is 1.0-fold (0.02 log units) above the measured one, within the range that was stated.
By their numbers in this assay, from the lowest: compounds 4, 3, 2 and 1 (each within the scatter of the next).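

In this assay, going by these compounds alone, a 1.1-fold lower number from compound 2 to compound 4 (0.04 log units; within the scatter) shows that this position accepts bromine, which no earlier compound carried, with no step beyond the scatter. The change on a double-bonded chain carbon bound to a double-bonded ring carbon also replaces the 2-fluorophenyl group as a whole, and compound 4 stays in the same flat group as compounds 1, 2 and 3. Nothing available explains this flatness.

As far as these compounds go, whether an amine or a carboxylic acid on this aryl group would give a step beyond the scatter remains open.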